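Ascorbic-acid-derived triazoles tested against HepG2 cells

The source may report more compounds than this note shows. Statements on the series, on what has been measured and on what is new or still open speak of the compounds shown alone.

Measured so far:
- compound 1 `O=C1O[C@H]([C@@H](O)Cn2cc(CNS(=O)(=O)c3ccc(Cl)cc3F)nn2)C(OCc2ccccc2)=C1OCc1ccccc1`: 25500 nM
- compound 2 `O=C1O/C(=C\Cn2cc(-c3cccc(O)c3)nn2)C(OCc2ccccc2)=C1OCc1ccccc1`: 61700 nM
- compound 3 `CC(C)(C)OC(=O)N1CCN(C(=S)SCc2cn(C[C@H](O)[C@H]3OC(=O)C(OCc4ccccc4)=C3OCc3ccccc3)nn2)CC1`: > 100000 nM

Three compounds built on the shared core have been examined in a functional assay on HepG2 cells (Homo sapiens) for antiproliferative activity, read by MTT assay, with a stated time of 72 h; a higher number here means a weaker inhibitor, a lower number a stronger inhibitor. Compound 1 gives 25500 nM in this assay. Compound 2 gives 61700 nM in this assay. For compound 3, this assay reports only a limit, > 100000 nM, rather than a number; this is the situation described by the limit of > 100000 nM in this assay, at which 1 of the 3 values shown sits. Among the two numbers available, compound 1 stands lowest, and its gap to compound 2 lies beyond the scatter of the method.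

The next compound, compound 4 `CCCCCCCCCCc1cn(C[C@H](O)[C@H]2OC(=O)C(OCc3ccccc3)=C2OCc2ccccc2)nn1`, differs from compound 1 at one point: nonyl in place of ((4-chloro-2-fluorophenyl)sulfonyl)amino on a saturated chain carbon bound to an aromatic carbon.

Among the compounds with values here, no pair of measured compounds that differ in a single place is available, so the size of this step cannot be read from the data. Given that all three measured compounds sit at weak potency, the expectation is a step of no more than modest size in this assay, in either direction, and quite possibly none beyond the scatter. The estimate for compound 4 is 20000 nM in this assay, with a range from 5000 nM to 80000 nM. This estimate corresponds to an expected step of a 1.3-fold lower number from compound 1 to compound 4 (0.11 log units; within the scatter).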

Compound 4, half-maximal inhibitory concentration: 12200 nM
For compound 4 the middle estimate is 1.6-fold (0.21 log units) above the measured one, and the stated range covers the measured number.
By their numbers in this assay, from the lowest: compound 4; then compound 1; then compound 2. At a limit, above all of these: compound 3.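

In this assay, within the data shown here, the first step that can be read between compounds differing in one place is a 2.1-fold lower number from compound 1 to compound 4 (0.32 log units; beyond the scatter), and it shows that this position, on a saturated chain carbon bound to an aromatic carbon, accepts a very different group without a loss. The ((4-chloro-2-fluorophenyl)sulfonyl)amino group, with its six-membered aromatic ring and its hydrogen-bond donor, is therefore not needed for the activity seen here: nonyl, which has no ring and no hydrogen-bond donors or acceptors, gives a modestly lower number. Nothing in the data shown accounts for the direction of this step.

From the compounds shown here alone, it remains open whether a longer chain, a shorter chain or an amine at the same place would lower the number further, and whether the change comes from the nonyl chain itself or from the removal of the sulfonyl group. Steps involving compound 2 and compound 3 cannot be read, as each differs from the other compounds in more than one place.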